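Compound 3 to compound 4: 3-fluorobenzyl to 2-chlorobenzyl

A few compounds are considered here, and "the series" means these few. Any claim that something is new, unique, unknown or untested is made for them only; others in the source may bear on it.

Values in a functional assay on B16 cells (Mus musculus) for antiproliferative activity, read by MTT assay, with a stated time of 24 h; on this read-out lower numbers stand for stronger inhibition and higher numbers for weaker inhibition:
compound 1 `COc1cc(OC)c(-c2coc3cc(OCC=C(C)C)ccc3c2=O)cc1OC`: 1090 nM
compound 2 `COc1cc(OC)c(-c2coc3cc(OCc4ccccc4C)ccc3c2=O)cc1OC`: 2150 nM
compound 3 `COc1cc(OC)c(-c2coc3cc(OCc4cccc(F)c4)ccc3c2=O)cc1OC`: 2440 nM

Compound 3 stands at the high end of these numbers, together with compound 2. The two are separated by a 1.1-fold higher number from compound 2 to compound 3 (0.05 log units; within the scatter), while a 2.2-fold higher number from compound 1 to compound 3 (0.35 log units; beyond the scatter) is modest.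

Next is compound 4 `COc1cc(OC)c(-c2coc3cc(OCc4ccccc4Cl)ccc3c2=O)cc1OC`, not yet measured, with 2-chlorophenyl in place of 3-fluorophenyl on a saturated chain carbon bound to an oxygen on an aromatic ring.

Among the compounds with values here, the closest precedent is the exchange of one substituted phenyl for another, a 1.1-fold higher number from compound 2 to compound 3 (0.05 log units; within the scatter). The measured steps from compound 1, a 2.0-fold higher number from compound 1 to compound 2 (0.30 log units; within the scatter) and a 2.2-fold higher number from compound 1 to compound 3 (0.35 log units; beyond the scatter), replace 2-methylprop-1-en-1-yl and bear less directly. No step beyond the scatter is expected in this assay, and the estimate is a 1.1-fold lower number from compound 3 to compound 4 (0.04 log units; within the scatter).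

Compound 4 is expected at 2200 nM (estimated range 1100 nM to 4400 nM).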

Compound 4, half-maximal inhibitory concentration: 4180 nM
Compound 4: the middle estimate sits 1.9-fold (0.28 log units) below what was measured; measured number inside the range.
By their numbers in this assay, from the lowest: compounds 1, 2, 3 and 4 (each within the scatter of the next, the first and the last beyond it).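

In this assay the change from 3-fluorophenyl to 2-chlorophenyl on this saturated chain carbon stays within the scatter (a 1.7-fold higher number from compound 3 to compound 4 (0.23 log units; within the scatter)), as does chloro in place of methyl on the aromatic carbon (a 1.9-fold higher number from compound 2 to compound 4 (0.29 log units; within the scatter)), so these aryl exchanges do not yet resolve. Within the data shown here, the step from the 2-methylprop-1-en-1-yl group (a 3.8-fold higher number from compound 1 to compound 4 (0.58 log units; beyond the scatter)) is the widest gap so far. No measurement available here accounts for these differences.

On these data alone, whether an unsubstituted benzyl, a longer alkyl chain or an amine-bearing chain at this position would separate from these compounds stays open.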